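A few compounds are considered here, and "the series" means these few. Any claim that something is new, unique, unknown or untested is made for them only; others in the source may bear on it.

Measured so far:
compound 1, `C[C@@H](Sc1nc2c(cnn2C)c(=O)n1-c1ccccc1)c1ccccc1`: 70 nM
compound 2, `Cn1ccc2c(=O)n(-c3ccccc3)c(SCc3cccc(F)c3)nc21`: 930 nM
compound 3, `Cn1ncc2c(=O)n(-c3ccccc3)c(OCc3cccc(F)c3)nc21`: 775 nM

In an assay on isolated protein for inhibition of aldehyde dehydrogenase 1A1 (Homo sapiens) (a higher number here means a weaker inhibitor, a lower number a stronger inhibitor), compound 1 gives 70 nM, the lowest number of the three, and its gaps to compound 3 and to compound 2 both lie beyond the scatter. Compound 4, `CC(Sc1nc2c(cnn2C)c(=O)n1-c1ccccc1)c1ccccc1`, has not yet been measured in this assay. It differs from compound 1 as follows: the two compounds have the same atoms and bonds; at least one stereo element is drawn with a configuration in one of them and without one in the other: 1 of 1 stereo elements differ; a stereocentre at a saturated chain carbon is drawn R in compound 1 and without a configuration in compound 4. Going by the values given here, no step between two measured compounds addresses this kind of change, so there is nothing to calibrate against. If the drawn configuration of compound 1 carries the activity, the undefined material of compound 4 should sit somewhat higher, within or just past the scatter. The step from compound 1 to compound 4 is expected to be a 1.9-fold higher number from compound 1 to compound 4 (0.27 log units; within the scatter). Compound 4 is estimated at 130 nM, in a range of 55 nM to 320 nM.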

Compound 4, half-maximal inhibitory concentration: 130 nM
Estimate against measurement, compound 4: no gap at the digits printed; the measured number falls inside the stated range.
By their numbers in this assay, from the lowest: compounds 1 and 4 (each within the scatter of the next); then compounds 3 and 2 (each within the scatter of the next).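

In this assay the stereocentre at the saturated chain carbon gets its first reading: a 1.9-fold higher number from compound 1 to compound 4 (0.27 log units; within the scatter). Whether this centre is drawn R or without a configuration therefore makes no difference that can be separated from the scatter. The pair differs in nothing else: the fact that one of compounds 1 and 4 is drawn with a defined configuration and the other without, at the place where they differ

Still open, from the compounds shown here alone, is how the centre drawn S would read on its own. Also open, going by these compounds, is whether an ethyl group in place of the methyl group at this saturated chain carbon would keep the number in the same range.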